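This account rests on a few compounds, and the source may have more. Where it says the series, first, only, none or still open, it means among the compounds named here.

Compound 1 `CCn1cc(-c2nc3ccccc3[nH]2)c(=O)c2cc(F)c(N3CCNCC3)nc21` and compound 2 `CCn1cc(-c2nc3ccccc3s2)c(=O)c2cc(F)c(N3CCNC(C)C3)c(F)c21` share the idea of a fused aromatic group attached to a bicyclic core, but the difference between the two cores is not broken down here. In a functional assay on A2780 cells (Homo sapiens) for cytotoxicity, read by MTT assay, with a stated time of 48 h (on this read-out higher numbers stand for weaker inhibition and lower numbers for stronger inhibition), compound 1 gives 4800 nM and compound 2 gives 9800 nM. Compound 3 `CCn1cc(-c2nc3ccc([N+](=O)[O-])cc3[nH]2)c(=O)c2cc(F)c(N3CCNCC3)nc21` is compound 1 with one change (nitro in place of hydrogen on an aromatic carbon). In this assay compound 3 gives 12400 nM, so the step of a 2.6-fold higher number from compound 1 to compound 3 (0.41 log units; beyond the scatter) is a modest weakening. Compound 4 `CCn1cc(-c2nc3ccc([N+](=O)[O-])cc3s2)c(=O)c2cc(F)c(N3CCNC(C)C3)c(F)c21` is compound 2 carrying the same change nitro in place of hydrogen on an aromatic carbon at the same place, and it has not yet been measured in this assay. Since the change is the same and sits in the same surroundings, the step from compound 2 to compound 4 in this assay is expected to resemble the step seen from compound 1 to compound 3, that is a 2.6-fold higher number from compound 2 to compound 4 (0.41 log units; beyond the scatter), although one prior example is a thin basis. Compound 4 is therefore estimated to give about 25000 nM in this assay, with a plausible range from 12000 nM to 50000 nM.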

Compound 4, half-maximal inhibitory concentration: 3300 nM
Estimate against measurement, compound 4: 7.6-fold (0.88 log units) above; the whole stated range lies above it.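

In this assay, nitro in place of hydrogen on the aromatic carbon gives a 3.0-fold lower number from compound 2 to compound 4 (0.47 log units; beyond the scatter) and so marks stronger inhibition on this core. Set beside the earlier step, the same change does not carry over from one core to the other, and its direction reverses: the same change on two cores in this assay, a 2.6-fold higher number (0.41 log units; beyond the scatter) from compound 1 to compound 3 and a 3.0-fold lower number (0.47 log units; beyond the scatter) from compound 2 to compound 4, 7.7-fold (0.88 log units) apart, beyond the scatter of two such steps. This shows that, in this series, a step measured on one core is not a safe guide to the same step on the other, but two pairs do not show what in the cores decides the direction, nor how the change would behave on any further core.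

The compounds shown leave open whether a different group at the same place, such as a nitrile or a carboxylic acid, would also move in opposite directions on the two cores. Among the compounds shown here, they also leave open which single difference between the cores matters, as the two cores differ in more than one place and no compound here separates those differences.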